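The compounds below may be only part of what the source reports. "The series", "measured", "known", "first", "only" and "open" are said of these compounds alone.

Among the compounds with values here, only two compounds have numbers so far in a toxicity assay on cells (Macrophage, Mus musculus, strain BALB/c) for cytotoxicity, read by MTT assay; on this read-out lower numbers stand for stronger inhibition and higher numbers for weaker inhibition. There, compound 1 (`C=CCOc1cc(OC)c(C(=O)/C=C/c2ccc(F)cc2)c(OCC=C)c1`) gives 13800 nM and compound 2 (`COc1cc(O)cc(O)c1C(=O)/C=C/c1ccc(C)cc1`) gives 16500 nM. These two values lie within the usual scatter of repeated measurements, so compound 2 cannot be told apart from compound 1. The two compounds differ in more than one place, so no clean single-change comparison exists yet.

The next compound, compound 3 (`COc1cc(O)cc(O)c1C(=O)/C=C/c1ccc(F)cc1`), is compound 2 with one small edit: fluoro in place of methyl on an aromatic carbon. This puts fluoro in place of methyl on an aromatic carbon, turning 4-methylphenyl to 4-fluorophenyl. Within the data shown here, no measured pair shows this swap directly, so the expectation rests on thin evidence. Compound 1 already carries the 4-fluorophenyl group and gives 13800 nM, so no step beyond the scatter is expected in this assay, and no direction can be favoured. The estimated change, a 1.1-fold lower number from compound 2 to compound 3 (0.04 log units; within the scatter), is therefore expected to be small. For compound 3 the expected value is 15000 nM, with an estimated range from 7000 nM to 32000 nM.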

Compound 3, half-maximal inhibitory concentration: 28800 nM
Compound 3: middle estimate off by 1.9-fold (0.28 log units), on the low side; low and high end bracket the measured number.
By their numbers in this assay, from the lowest: compounds 1, 2 and 3 (each within the scatter of the next, the first and the last beyond it).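

In this assay, the swap from 4-methylphenyl to 4-fluorophenyl gives the first clean single-change comparison among these compounds, with a 1.7-fold higher number from compound 2 to compound 3 (0.24 log units; within the scatter) as its step. Methyl and fluoro, each a single heavy atom on an aromatic carbon para to a large group, therefore cannot be told apart on these cells, and this one pair gives no firm sign that the choice between them matters for cytotoxicity. No measurement shown here offers an explanation for this outcome.

The compounds shown leave open whether a different group at this position, such as an amine, a carboxylic acid or a longer alkyl chain, would give a step beyond the usual scatter. They also leave open whether the swap from 4-methylphenyl to 4-fluorophenyl would read the same on the core of compound 1, since only the 4-fluorophenyl form of that core appears here.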